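A Hydroxy Group on a Saturated Ring: Three Measured, One Expected

The source may report more compounds than this note shows. Statements on the series, on what has been measured and on what is new or still open speak of the compounds shown alone.

Compound 1, `Cc1cc(N2CCCCC2)c(S(C)(=O)=O)cc1C(=O)N=C(N)N`, in a functional assay for inhibition of sodium/hydrogen exchanger (Oryctolagus cuniculus); a higher number here means a weaker inhibitor, a lower number a stronger inhibitor: 21 nM
Compound 2, `Cc1cc(N2CCCC(O)C2)c(S(C)(=O)=O)cc1C(=O)N=C(N)N`, in this assay: 30 nM
Compound 3, `CCc1cc(N2CCCCC2)c(S(C)(=O)=O)cc1C(=O)N=C(N)N`, in this assay: 25 nM

Compound 2 differs from compound 1 by hydroxy in place of hydrogen on a saturated ring carbon, and this change gave a 1.4-fold higher number from compound 1 to compound 2 (0.15 log units; within the scatter). Compound 3 differs from compound 1 by methyl in place of hydrogen on a saturated chain carbon bound to an aromatic carbon, with a 1.2-fold higher number from compound 1 to compound 3 (0.08 log units; within the scatter). Compound 4 `CCc1cc(N2CCC(O)CC2)c(S(C)(=O)=O)cc1C(=O)N=C(N)N` is not yet measured; it differs from compound 3 by hydroxy in place of hydrogen on a saturated ring carbon. Within the data shown here, this is the same kind of change as the one from compound 1 to compound 2, but not the same: there the hydroxy sits two ring bonds from the ring nitrogen and two ring bonds from the ring atom that bears a large group, here three ring bonds from each. Since the hydroxy in compound 2 barely moved the number, as seen in a 1.4-fold higher number from compound 1 to compound 2 (0.15 log units; within the scatter), a step of similar size is expected from compound 3, namely a 1.4-fold higher number from compound 3 to compound 4 (0.15 log units; within the scatter). Compound 4 is therefore estimated at 35 nM, most likely between 15 nM and 80 nM.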

Compound 4, half-maximal inhibitory concentration: 41 nM
For compound 4 the middle estimate is 1.2-fold (0.07 log units) below the measured one, within the range that was stated.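

Going from piperidin-1-yl to 4-hydroxypiperidin-1-yl, this assay records a 1.6-fold higher number from compound 3 to compound 4 (0.21 log units; within the scatter) and so no clear loss or gain. Set beside the earlier hydroxy step, the change carries from one core to the other with no difference that can be told from noise: the same change on two cores in this assay, a 1.4-fold higher number (0.15 log units; within the scatter) from compound 1 to compound 2 and a 1.6-fold higher number (0.21 log units; within the scatter) from compound 3 to compound 4, 1.1-fold (0.06 log units) apart, within the scatter of two such steps. Among these compounds, this rests on only two pairs, and the hydroxy sits on a different ring carbon in compound 2 and compound 4 while the cores differ too, so the effect of position cannot be separated from that of the core.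

Still open, as far as these compounds go, is whether an amine or a carboxylic acid on the same ring carbon would also leave the number within the scatter. The same question stands for a longer chain where compound 1 and compound 3 differ.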